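The compounds below may be only part of what the source reports. "The series", "measured", "known", "first", "only" and "open" are said of these compounds alone.

Compound 1 `CCc1nc(C)c(CN2CCN(c3cccc4[nH]c(-c5ccc(C(C)(C)C)cc5)nc34)CC2)s1` gives 20 nM in an assay on isolated protein for displacement of a labelled ligand from Gonadotropin-releasing hormone receptor (Homo sapiens); a lower number here means a stronger inhibitor, a higher number a weaker inhibitor. Compound 2 `CCCCc1nc(CN2CCN(c3cccc4[nH]c(-c5ccc(C(C)(C)C)cc5)nc34)CC2)cn1C` gives 26 nM in this assay.

Compound 2 holds the highest of the two numbers, yet the step of a 1.3-fold higher number from compound 1 to compound 2 (0.11 log units; within the scatter) is within the scatter, so the two compounds cannot be told apart. Compound 3 `CCn1cc(CN2CCN(c3cccc4[nH]c(-c5ccc(C(C)(C)C)cc5)nc34)CC2)nc1C` differs from compound 2 by 1-ethyl-2-methyl-1H-imidazol-4-yl in place of 2-butyl-1-methyl-1H-imidazol-4-yl on a saturated chain carbon bound to an amine nitrogen in a ring. Among the measured compounds shown here, the only measured step bearing on this position, from compound 1 to compound 2, swapped one small aromatic ring for another with no change beyond the scatter. The same is therefore expected here, with no step beyond the scatter in this assay. Compound 3 is estimated at 28 nM, ranging from 10 nM to 80 nM, which is an expected step of a 1.1-fold higher number from compound 2 to compound 3 (0.03 log units; within the scatter).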

Compound 3, half-maximal inhibitory concentration: 10 nM
For compound 3 the middle estimate is 2.8-fold (0.45 log units) above the measured one; the range from low to high includes it.
By their numbers in this assay, from the lowest: compounds 3, 1 and 2 (each within the scatter of the next, the first and the last beyond it).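

Moving from one imidazole group to the other matters at this position: in this assay, 1-ethyl-2-methyl-1H-imidazol-4-yl in place of 2-butyl-1-methyl-1H-imidazol-4-yl gives a 2.6-fold lower number from compound 2 to compound 3 (0.41 log units; beyond the scatter), the first step here beyond the scatter. The thiazole swap, by contrast, gives a 2.0-fold lower number from compound 1 to compound 3 (0.30 log units; within the scatter), so compound 1 and compound 3 cannot be told apart. No evidence is available on what lies behind the imidazole step.

Both alkyl groups on the imidazole differ between compound 2 and compound 3, leaving open which one carries the step. As far as these compounds go, whether an amine or a carboxylic acid would be tolerated on this ring also remains open.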